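The source may report more compounds than this note shows. Statements on the series, on what has been measured and on what is new or still open speak of the compounds shown alone.

Measured compounds in an assay on isolated protein for inhibition of Dihydrofolate reductase (Homo sapiens), read by spectrophotometry, using NADPH, with stated times of 5 s and 6 min, tested at 5 uM; on this read-out higher numbers stand for a stronger effect at the one concentration tested and lower numbers for a weaker effect:
- compound 1, `CC(C)(C)c1ccc(OCCCON2C(N)=NC(N)=NC23CCSCC3)cc1`: 85.3%
- compound 2, `NC1=NC2(CCOCC2)N(OCCCOc2cccc(Cl)c2Cl)C(N)=N1`: 81.7%
- compound 3, `NC1=NC2(CCOCC2)N(OCCCOc2ccc(F)cc2)C(N)=N1`: for compound 3 the value is a limit of the assay, > 90%

For the measured compounds named here, compound 3 stands at the limit of the read-out (the limit of > 90% in this assay, at which 1 of the 3 values shown sits), and it is the one compound of the three reported only as a limit, so its position relative to compound 1 and compound 2 is not fixed by a number.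

Compound 4, `NC1=NC2(CCOCC2)N(OCCCOc2cccc(Br)c2)C(N)=N1`, differs from compound 3 by 3-bromophenyl in place of 4-fluorophenyl on an oxygen on a saturated carbon. Going by the values given here, one measured step bears on this place: a number at least 8.3 percentage points higher from compound 2 to compound 3 (that floor lies within the scatter). That step also exchanged the aryl group on the oxygen on the saturated carbon, and its floor lies within the scatter, so an exchange of the aryl group at this place has so far not shown a step clearly beyond the scatter. Among the compounds with values here, no further measured step touches this position. The exchange from compound 3 to compound 4 is therefore expected to move this assay by no more than the scatter, in either direction, with the limit capping any rise; because compound 3 shows only > 90%, a plain number within the measurable range for compound 4 is about as likely as a repeated limit.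

Compound 4 is estimated at 87%, with a range of 72% to 95%. The expected step is a number at least 3 percentage points lower from compound 3 to compound 4 (that floor lies within the scatter).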

Compound 4, a percentage reported as inhibition, at one concentration (the size of the read-out at that concentration, not a potency): 86.7%
Compound 4: middle estimate off by 0.3 percentage points, on the high side; measured number inside the range.
By their numbers in this assay, from the lowest: compounds 2, 1 and 4 (each within the scatter of the next). At a limit, above all of these: compound 3.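

In this assay, for the compounds shown here, the change from 4-fluorophenyl to 3-bromophenyl on an oxygen on a saturated carbon gives a number at least 3.3 percentage points lower from compound 3 to compound 4 (that floor lies within the scatter), so this second aryl exchange at the place also shows no step clearly beyond the scatter. Going by these compounds alone, the step to compound 4 from the 2,3-dichlorophenyl compound is the first at this place read between two plain numbers, and it gives a number 5 percentage points higher from compound 2 to compound 4 (within the scatter), which leaves 3-bromophenyl and 2,3-dichlorophenyl unseparated. The value of compound 3 is a limit, and the step from it is therefore known only as a floor: the limit of > 90% in this assay, at which 1 of the 4 values shown sits.

The compounds shown leave open whether any group at this place can move the read-out clearly beyond the scatter, for instance a phenyl ring carrying a carboxylic acid or an amine, or a plain alkyl chain in place of the aryl group. With a single tested concentration, they also leave open how far the three aryl groups on the shared core would differ in potency.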